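This account rests on a few compounds, and the source may have more. Where it says the series, first, only, none or still open, it means among the compounds named here.

In a functional assay on NCI-H460 cells (Homo sapiens) for inhibition, read by sulforhodamine B assay, with a stated time of 48 h (a lower number here means a stronger inhibitor of growth, a higher number a weaker inhibitor of growth), compound 2 `COc1cc(-c2nn(-c3cccc(NC(=O)Nc4ccc(Cl)c(C(F)(F)F)c4)c3)cc2-c2ccncc2)ccc1Cl` gives 4790 nM. Among the compounds with values here, of the two numbers so far it is numerically the higher one, while compound 1 `COc1cc(-c2nn(-c3cccc(NC(=O)Nc4cccc(C(F)(F)F)c4)c3)cc2-c2ccncc2)ccc1Cl` gives 3530 nM; the step of a 1.4-fold higher number from compound 1 to compound 2 (0.13 log units; within the scatter) lies within the scatter, so the two compounds are not told apart. Compound 3 `COc1cc(-c2nn(-c3cccc(NC(=O)c4ccccc4)c3)cc2-c2ccncc2)ccc1Cl` differs from compound 2 by phenyl in place of (4-chloro-3-(trifluoromethyl)phenyl)amino on a carbonyl carbon. Within the data shown here, the only measured step swapped a hydrogen for chloro on an aromatic carbon and stayed within the scatter, so it does not cover a change of this kind, and the expectation rests on little. The step of a 1.9-fold higher number from compound 2 to compound 3 (0.27 log units; within the scatter) is expected to reach beyond the scatter toward a higher number. Compound 3 is estimated at 9000 nM, within a range from 2500 nM to 40000 nM.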

Compound 3, concentration for total growth inhibition: > 100000 nM
Compound 3 was reported as a limit (the forecaster's own chance of this, stated with the estimate: 15%); middle value at least 11-fold (1.04 log units) from the limit.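

Swapping hydrogen for chloro changed nothing that could be told apart, but the whole group on the carbonyl carbon matters far more: phenyl in place of (4-chloro-3-(trifluoromethyl)phenyl)amino gives an at least 20-fold higher number from compound 2 to compound 3 (1.31 log units; beyond the scatter) and phenyl in place of (3-(trifluoromethyl)phenyl)amino gives an at least 28-fold higher number from compound 1 to compound 3 (1.45 log units; beyond the scatter) as the second step. Compound 3 is reported only as a limit: the limit of > 100000 nM in this assay, at which 1 of the 3 values shown sits.

These steps remove the nitrogen with its hydrogen and the ring substituents together, so the compounds shown cannot tell which part counts. As far as these compounds go, whether a plain phenylamino group on the same carbonyl carbon would keep growth inhibition remains open.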